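Chloromethylbenzyl purines: effect of removing one chlorine

This account rests on a few compounds, and the source may have more. Where it says the series, first, only, none or still open, it means among the compounds named here.

Measured compounds and their values in a functional assay on OVCAR-5 cells (Homo sapiens) for cytotoxicity, read by sulforhodamine B assay, with a stated time of 48 h; a lower number here means a stronger inhibitor of growth, a higher number a weaker inhibitor of growth:
compound 1 `ClCc1cccc(Cn2cnc3ncnc(Cl)c32)c1` gives 20000 nM
compound 2 `ClCc1ccc(Cn2cnc3nc(Cl)nc(Cl)c32)cc1` gives 4260 nM
compound 3 `ClCc1cccc(Cn2cnc3nc(Cl)nc(Cl)c32)c1` gives 3230 nM

Compound 2 and compound 3 have the same atoms joined differently; the difference between the two cores is not broken down here, and their two values lie within the scatter. Compound 3 and compound 1 differ by hydrogen in place of chloro on an aromatic carbon, which gave a 6.2-fold higher number from compound 3 to compound 1 (0.79 log units; beyond the scatter).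

Compound 4 `ClCc1ccc(Cn2cnc3ncnc(Cl)c32)cc1` is not yet measured. It differs from compound 2 by hydrogen in place of chloro on an aromatic carbon, the same change as between compound 3 and compound 1, at the same place. Because a 6.2-fold higher number from compound 3 to compound 1 (0.79 log units; beyond the scatter) was seen for this change, a step of similar size is expected for compound 4, a 5.2-fold higher number from compound 2 to compound 4 (0.71 log units; beyond the scatter). In this assay compound 4 is thus estimated at 22000 nM, with an expected range from 8000 nM to 60000 nM.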

Compound 4, concentration for total growth inhibition: 19500 nM
Beside the measured number, compound 4's estimate is 1.1-fold (0.05 log units) above it, and the stated range covers the measured number.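

In this assay, hydrogen in place of chloro on an aromatic carbon gives a 4.6-fold higher number from compound 2 to compound 4 (0.66 log units; beyond the scatter), and this step does not differ from the one seen on the other core: the same change on two cores in this assay, a 6.2-fold higher number (0.79 log units; beyond the scatter) from compound 3 to compound 1 and a 4.6-fold higher number (0.66 log units; beyond the scatter) from compound 2 to compound 4, 1.4-fold (0.13 log units) apart, within the scatter of two such steps. The change therefore carries over between the two cores shown, which have the same atoms joined differently. Within the data shown here, this rests on only two pairs in a single assay, so it does not show that the step would hold on any other core, and it gives no reason for the step.

Still open, from the compounds shown here alone, is how an amine or a methoxy group would compare with chloro and hydrogen at that place between two ring nitrogen atoms. Also open, going by these compounds, is what a hydroxymethyl group in place of the chloromethyl group would do on either core.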